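The source may hold more compounds than are shown below. What is called first, only, known or untested is meant among the compounds shown, and "the series" means these compounds.

Measured so far in a functional assay on NCI-H727 cells (Homo sapiens), read by fluorescence and BrdU incorporation, with a stated time of 48 h, tested at 10 uM; a lower number here means a stronger effect, a higher number a weaker effect of the compound at the concentration tested:
- compound 1 `COc1cc(O)c(C(=O)/C=C/c2ccc(F)cc2)c(OC)c1` gives "not active" (no number reported)
- compound 2 `COc1cc(OC)c(C(=O)/C=C/c2ccccc2SC)c(OC)c1` gives 35%
- compound 3 `COc1cc(OC)c(C(=O)/C=C/c2ccccc2)c(OC)c1` gives 34%

Among the compounds with values here, compound 3 holds the lowest of the two numbers in this assay, but its nearest neighbour, compound 2, lies within the scatter: the only computed step, a number 1 percentage points lower from compound 2 to compound 3 (within the scatter), is too small to count as a change. Within the data shown here, compound 1 carries no number at all and shares neither the core nor the substitution of compound 3, so it gives no step to lean on.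

Compound 4 `COc1cc(OC)c(C(=O)/C=C/c2ccc(F)cc2)c(OC)c1` keeps the core of compound 3 and differs from it in one place: fluoro in place of hydrogen on an aromatic carbon. The group enters on an aromatic carbon of a six-membered aromatic ring of carbon only, para to a large group. Among the measured compounds shown here, no measured step touches this position or this group; the single step available, from a methylsulfanyl to a hydrogen elsewhere on the same ring, stayed within the scatter. For the measured compounds named here, with no step in this assay pointing either way, the expected change a number 3 percentage points higher from compound 3 to compound 4 (within the scatter) is none beyond the scatter, with the uncertainty widened for want of any directly comparable pair. The estimate for compound 4 in this assay is therefore 37%, ranging from 20% to 60%.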

Compound 4, a percentage reported as activity, at one concentration (the size of the read-out at that concentration, not a potency): 31%
Estimate against measurement, compound 4: 6 percentage points above; the range from low to high includes it.
By their numbers in this assay, from the lowest: compounds 4, 3 and 2 (each within the scatter of the next).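

In this assay, within the data shown here, phenyl to 4-fluorophenyl gives a number 3 percentage points lower from compound 3 to compound 4 (within the scatter), the first reading for a group on an aromatic carbon para to a large group, and the replacement of 2-(methylsulfanyl)phenyl by 4-fluorophenyl gives a number 4 percentage points lower from compound 2 to compound 4 (within the scatter), so neither step separates these compounds. Compound 4 also gives compound 1 a partner differing in one place, a methoxy on the shared core where compound 1 has a hydroxy: compound 1 gives "not active" (no number reported) and compound 4 gives 31%, so the 4-fluorophenyl group alone does not fix the outcome in this series. No supporting data bear on why the fluoro step stays within the scatter or why this pair reads as it does.

Whether an amine or a carboxylic acid at the same position would give a step beyond the scatter remains open, since fluoro is the only group shown there. Also open is whether the hydroxy of compound 1 would give the same reading with an unsubstituted phenyl, and how any of these compounds would compare across a range of concentrations rather than at the single one tested.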